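From thiophen-3-yl to 1-benzofuran-2-yl on a shared core

The source may hold more compounds than are shown below. What is called first, only, known or untested is meant among the compounds shown, and "the series" means these compounds.

- Compound 1 `COc1ncnc2c1c(-c1cc3ccccc3o1)cn2[C@@H]1O[C@H](CO)[C@@H](O)[C@H]1O` gives 13100 nM
- Compound 2 `CNc1ncnc2c1c(-c1ccco1)cn2[C@@H]1O[C@H](CO)[C@@H](O)[C@H]1O` gives 15100 nM
- Compound 3 `CNc1ncnc2c1c(-c1ccsc1)cn2[C@@H]1O[C@H](CO)[C@@H](O)[C@H]1O` gives > 20000 nM (a limit)

All three results come from a functional assay on K562 cells (Homo sapiens), read by MTT assay, with a stated time of 72 h; on this read-out higher numbers stand for weaker inhibition and lower numbers for stronger inhibition (one of them a limit, not a number). Compound 3 stands only at a limit (that is, > 20000 nM) and has no exact value.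

Compound 4 `CNc1ncnc2c1c(-c1cc3ccccc3o1)cn2[C@@H]1O[C@H](CO)[C@@H](O)[C@H]1O` differs from compound 3 by one change: 1-benzofuran-2-yl in place of thiophen-3-yl on an aromatic carbon.

Within the data shown here, the one measured step at this place is an at least 1.3-fold higher number from compound 2 to compound 3 (0.12 log units; that floor lies within the scatter) (a floor, so it gives only weak guidance). The closest guide is compound 1 at 13100 nM (it also carries 1-benzofuran-2-yl but differs elsewhere on the shared core).

A modest expected move toward stronger inhibition follows, and the estimated step is an at least 1.5-fold lower number from compound 3 to compound 4 (0.18 log units; that floor lies within the scatter) (a rough figure, since it starts from a limit).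

The estimate for compound 4 is 13000 nM (expected range 6000 nM to 20000 nM).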

Compound 4, half-maximal inhibitory concentration: > 20000 nM
Compound 4 gave a limit, no number; the forecaster's own chance of this, stated with the estimate: 25%; middle value at least 1.5-fold (0.18 log units) away from the limit.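

In this assay compound 4 gives > 20000 nM, which is a limit, so 1-benzofuran-2-yl at this place gives no exact value when methylamino is also present. Only floors can be read, an at least 1.3-fold higher number from compound 2 to compound 4 (0.12 log units; that floor lies within the scatter) and an at least 1.5-fold higher number from compound 1 to compound 4 (0.18 log units; that floor lies within the scatter), so neither the furan-2-yl swap nor the methoxy swap has a known size. The step between compound 3 and compound 4 cannot be read because both values are limits: the limit of > 20000 nM in this assay, at which 2 of the 4 values shown sit.

Going by these compounds, it remains open whether a longer chain in place of methylamino, or an amine on the 1-benzofuran-2-yl group, would give an exact value.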